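The source may hold more compounds than are shown below. What is called first, only, known or untested is meant among the compounds shown, and "the series" means these compounds.

Compound 1, `CC[C@@](C)(O)CC(=O)O[C@H](CC=C(C)C)C1=CC(=O)c2c(O)ccc(O)c2C1=O`: in a functional assay on DU-145 cells (Homo sapiens) for cytotoxicity, read by MTT assay (a higher number here means a weaker inhibitor, a lower number a stronger inhibitor), compound 1 gives 12700 nM.
Compound 2, `CCCC(C)(O)CC(=O)O[C@H](CC=C(C)C)C1=CC(=O)c2c(O)ccc(O)c2C1=O`: compound 2 gives 75000 nM.
Compound 3, `CC(C)=CC[C@@H](OCCO)C1=CC(=O)c2c(O)ccc(O)c2C1=O`: compound 3 gives 9900 nM.

Compound 1 stands second highest of these three numbers. Its nearest neighbour is compound 3, a 1.3-fold lower number from compound 1 to compound 3 (0.11 log units; within the scatter); its furthest is compound 2, a 5.9-fold higher number from compound 1 to compound 2 (0.77 log units; beyond the scatter).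

Compound 4, `CCC(CO[C@H](CC=C(C)C)C1=CC(=O)c2c(O)ccc(O)c2C1=O)OC`, differs from compound 1 in one place: 2-methoxybutyl in place of (2-hydroxy-2-methylbutyl)carbonyl on an oxygen on a saturated carbon. Within the data shown here, the step that bears most on this is the one from compound 1 to compound 3, where 2-hydroxyethyl took the place of (2-hydroxy-2-methylbutyl)carbonyl on the same oxygen, a 1.3-fold lower number from compound 1 to compound 3 (0.11 log units; within the scatter). The step from compound 2 to compound 3 was larger, a 7.6-fold lower number from compound 2 to compound 3 (0.88 log units; beyond the scatter), but starts from a different chain. Replacing the ester side chain by a short ether is therefore expected to move the number little, a 1.2-fold lower number from compound 1 to compound 4 (0.06 log units; within the scatter). Compound 4 is expected to give 11000 nM, in the range 4000 nM to 30000 nM.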

Compound 4, half-maximal inhibitory concentration: 45700 nM
Beside the measured number, compound 4's estimate is 4.2-fold (0.62 log units) below it; measured number above the stated range.
By their numbers in this assay, from the lowest: compounds 3 and 1 (each within the scatter of the next); then compounds 4 and 2 (each within the scatter of the next).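

Ether side chains on this oxygen do not all behave alike: 2-methoxybutyl in place of hydroxymethyl's parent chain is not neutral, as the change to 1-methoxypropyl on the saturated chain carbon gives a 4.6-fold higher number from compound 3 to compound 4 (0.66 log units; beyond the scatter). Replacing the ester of compound 1 with 2-methoxybutyl also counts against a simple swap, with a 3.6-fold higher number from compound 1 to compound 4 (0.56 log units; beyond the scatter), while the ester of compound 2 gives a 1.6-fold lower number from compound 2 to compound 4 (0.22 log units; within the scatter). Nothing measured here explains these shifts. The compounds shown cannot separate the effect of the methoxy group from that of chain length. Going by these compounds, a 2-hydroxybutyl group or a terminal amine on this oxygen remains open.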